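The source may report more compounds than this note shows. Statements on the series, on what has been measured and on what is new or still open speak of the compounds shown alone.

Compound 1 `O=C(c1ccc(-c2ccc3ncc(-c4cnc5ccccc5c4)n3c2)cc1)N1CCOCC1` is a molecule in which the two ends of the structure differ from those of its companion. In an assay on Sf21 cells for inhibition of MAP kinase-interacting serine/threonine-protein kinase 1 (Homo sapiens), read by luminescence and ADP-Glo, with stated times of 10 min and 40 min, tested at 500 nM (a higher number here means more inhibition at the concentration tested (going by the name of the read-out), a lower number less inhibition), compound 1 gives 71%. Its single measured companion, compound 2 `O=C(c1ccc(-c2ccc3ncc(-c4cnc5ccccc5c4)n3c2)cc1)N1CCNCC1`, gives 70.7% in this assay. For the measured compounds named here, the one step that has been measured, a number 0.3 percentage points lower from compound 1 to compound 2 (within the scatter), concerns the group on the carbonyl carbon at the far end of the molecule. Compound 1 thus has the higher of the two numbers, but the gap to compound 2 is within the scatter, so the two cannot be told apart.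

Compound 3 `O=C(c1ccc(-c2ccc3ncc(-c4ccc5ncccc5c4)n3c2)cc1)N1CCOCC1` changes the other end of the shared core: quinolin-6-yl in place of quinolin-3-yl on an aromatic carbon. The same atoms are present, joined differently. Going by the values given here, no measured step touches this part of the molecule; the step from compound 1 to compound 2 concerns a different place and was within the scatter, so it gives no direction for this change. Compound 3 is therefore expected to stay near compound 1, with the step of a number 9 percentage points lower from compound 1 to compound 3 (within the scatter) expected to be small but uncertain. In this assay compound 3 is estimated at 62%, within a range from 30% to 85%.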

Compound 3, a percentage reported as inhibition, at one concentration (the size of the read-out at that concentration, not a potency): 74.7%
For compound 3 the middle estimate is 12.7 percentage points below the measured one, within the range that was stated.
By their numbers in this assay, from the lowest: compounds 2, 1 and 3 (each within the scatter of the next).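

The carbon that carries the quinoline, on a five-membered aromatic ring with 2 nitrogen, now has a measured step of its own: in this assay, quinolin-6-yl in place of quinolin-3-yl gives a number 3.7 percentage points higher from compound 1 to compound 3 (within the scatter). Changing how the quinoline is attached to the shared core, while keeping the same atoms, therefore produces no difference that this read-out can resolve, so both attachments are compatible with inhibition of this size at the one concentration tested. Nothing available offers a measured explanation for how these two quinoline attachments compare.

Because the read-out is a percentage at a single concentration rather than a potency, these compounds leave open whether the two attachments would still look alike across a range of concentrations. Also open, going by these compounds, is whether this position would give similar numbers with a smaller or quite different group, such as a single pyridine ring or a phenyl ring bearing a carboxylic acid, and whether quinolin-6-yl paired with piperazin-1-yl at the far end would read like compound 3.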